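Chain length and unsaturation in the series

The source may report more compounds than this note shows. Statements on the series, on what has been measured and on what is new or still open speak of the compounds shown alone.

Measured in a functional assay on MDA-MB-231 cells (Homo sapiens) for antiproliferative activity, read by MTT assay; a higher number here means a weaker inhibitor, a lower number a stronger inhibitor:
- compound 1 `CCCCCCCCCCCCCCCC1(O)CC(=O)c2c(O)cc(O)cc2O1`: 6790 nM
- compound 2 `CCCCC/C=C\C/C=C\CCCCCCCc1cc(=O)c2c(O)cc(O)c(C)c2o1`: 6790 nM
- compound 3 `CCCCCCCCCCCCCCCCCCCC1(O)CC(=O)c2c(O)cc(O)cc2O1`: > 87000 nM (a limit)

Compound 1 shares its value with compound 2, whose core and chain both differ. Compound 3 gives only a limit, > 87000 nM.

Compound 4 `CC/C=C\C/C=C\C/C=C\CCCCCCCC1(O)CC(=O)c2c(O)cc(O)cc2O1` carries the change (a group of 10 heavy atoms (10 carbon; no ring) in place of a group of 8 heavy atoms (8 carbon; no ring), on a saturated chain carbon, seven bonds along the chain from a saturated ring carbon), on a saturated chain carbon, seven bonds along the chain from a saturated ring carbon.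

Going by the values given here, the one measured step bearing on this is an at least 12-fold higher number from compound 1 to compound 3 (1.10 log units; beyond the scatter), where butyl extends the chain. Among the compounds with values here, the added length in compound 4 is smaller, and its double bonds have no matched measured step. A moderate move to a higher number is therefore expected, estimated as a 2.2-fold higher number from compound 1 to compound 4 (0.34 log units; beyond the scatter). For compound 4 the expected value is 15000 nM, with an estimated range of 5000 nM to 55000 nM.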

Compound 4, half-maximal inhibitory concentration: 6790 nM
Beside the measured number, compound 4's estimate is 2.2-fold (0.34 log units) above it; low and high end bracket the measured number.
By their numbers in this assay, from the lowest: compounds 1, 2 and 4 (each within the scatter of the next). At a limit, above all of these: compound 3.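

In this assay the group of 10 heavy atoms, with 3 double bonds outside aromatic rings, in place of octyl gives no change at the digits printed from compound 1 to compound 4 (within the scatter). This differs from the butyl extension, which gives an at least 12-fold higher number from compound 1 to compound 3 (1.10 log units; beyond the scatter), so added chain carbons do not always bring a large step in this series. Chain length and double bonds change together in compound 4, and nothing measured here accounts for the result.

The compounds shown leave open whether a fully saturated chain with the same heavy-atom count would match compound 4. They also leave open how a carboxylic acid at the chain end would read.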